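Series notes: methoxy to hydroxy on the chlorophenyl ring

A few compounds are considered here, and "the series" means these few. Any claim that something is new, unique, unknown or untested is made for them only; others in the source may bear on it.

Compound 1 `O=C(Nc1cccc(-n2cc(-c3ccncc3)c(-c3ccc(Cl)c(O)c3)n2)c1)Nc1cccc(C(F)(F)F)c1` in a functional assay on NCI-H226 cells (Homo sapiens) for inhibition, read by sulforhodamine B assay, with a stated time of 48 h (on this read-out lower numbers stand for stronger inhibition of growth and higher numbers for weaker inhibition of growth), gives > 32500 nM, a limit of the assay.
Compound 2 `COc1cc(-c2nn(-c3cccc(NC(=O)Nc4ccc(Cl)c(Cl)c4)c3)cc2-c2ccncc2)ccc1Cl` in this assay gives > 50000 nM, also a limit of the assay.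

Within the data shown here, compound 2 thus stands only at a limit (the limit of > 50000 nM in this assay, at which 1 of the 2 values shown sits); the one further value shown, for compound 1, is likewise a limit (the limit of > 32500 nM in this assay, at which 1 of the 2 values shown sits). Compound 3 `O=C(Nc1cccc(-n2cc(-c3ccncc3)c(-c3ccc(Cl)c(O)c3)n2)c1)Nc1ccc(Cl)c(Cl)c1` differs from compound 2 by hydrogen in place of methyl on an oxygen on an aromatic ring. Among the measured compounds shown here, no measured step exists between the compounds, and the hydroxy-bearing compound 1 sits at a limit (the limit of > 32500 nM in this assay, at which 1 of the 2 values shown sits), so no shift beyond the scatter is expected in either direction. Compound 3 is therefore estimated at 40000 nM, with a range of 8000 nM to 100000 nM, the expected step being an at least 1.2-fold lower number from compound 2 to compound 3 (0.09 log units; that floor lies within the scatter).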

Compound 3, concentration for total growth inhibition: > 32500 nM
Compound 3 was reported as a limit; the forecaster's own chance of this, stated with the estimate: 70%; the middle value does not contradict the limit.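

Compound 1, compound 2 and compound 3 all stand at limits of the assay, and no step can be read between compound 2 and compound 3 or between compound 1 and compound 3. From the compounds shown here alone, whether methoxy to hydroxy or 3,4-dichlorophenyl in place of 3-(trifluoromethyl)phenyl shifts growth inhibition at all stays open.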